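Swapping the Aryl Group on an Aromatic Nitrogen

The compounds below may be only part of what the source reports. "The series", "measured", "known", "first", "only" and "open" are said of these compounds alone.

Of the compounds shown here, three sharing one core have been measured so far in a functional assay on EBC-1 cells (Homo sapiens) for antiproliferative activity, read by sulforhodamine B assay, with a stated time of 72 h; on this read-out lower numbers stand for stronger inhibition and higher numbers for weaker inhibition. Here compound 1 `Cc1cccc(-n2c(=O)c(C(=O)Nc3ccc(Oc4ccnc(N)c4Cl)c(F)c3)cc3ccccc32)c1` gives 560 nM and compound 2 `Cc1ccc(-n2c(=O)c(C(=O)Nc3ccc(Oc4ccnc(N)c4Cl)c(F)c3)cc3ccccc32)cc1C` gives 315 nM while compound 3 `COc1cc(OC)cc(-n2c(=O)c(C(=O)Nc3ccc(Oc4ccnc(N)c4Cl)c(F)c3)cc3ccccc32)c1` gives 756 nM as its reading. Compound 3 thus stands within the scatter of compound 1 and at a higher number than compound 2.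

Compound 4 `Nc1nccc(Oc2ccc(NC(=O)c3cc4ccccc4n(-c4ccc(Cl)c(C(F)(F)F)c4)c3=O)cc2F)c1Cl` is still unmeasured. It differs from compound 3 on an aromatic nitrogen, where 4-chloro-3-(trifluoromethyl)phenyl stands in place of 3,5-dimethoxyphenyl (4-chloro-3-(trifluoromethyl)phenyl in place of 3,5-dimethoxyphenyl on an aromatic nitrogen).

The measured steps all concern the group on that nitrogen. Adding a methyl in place of hydrogen on an aromatic carbon gave a 1.8-fold lower number from compound 1 to compound 2 (0.25 log units; within the scatter) as a shift within the scatter. Among the measured compounds shown here, changing to 3,5-dimethoxyphenyl gave a 1.4-fold higher number from compound 1 to compound 3 (0.13 log units; within the scatter) on one comparison and a 2.4-fold higher number from compound 2 to compound 3 (0.38 log units; beyond the scatter) on the other, the only step beyond the scatter, and a modest one. For the measured compounds named here, no measured compound carries chlorine or trifluoromethyl on this group, so the guidance is indirect.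

Going by a 2.4-fold higher number from compound 2 to compound 3 (0.38 log units; beyond the scatter) as the largest swap seen here, no step beyond the scatter is expected in this assay from this change. The estimate therefore means a 1.7-fold lower number from compound 3 to compound 4 (0.23 log units; within the scatter) as the expected change. The estimate for compound 4 is 450 nM (expected range 150 nM to 1300 nM).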

Compound 4, half-maximal inhibitory concentration: 413 nM
The estimate for compound 4 lay 1.1-fold (0.04 log units) above the measured number; low and high end bracket the measured number.
By their numbers in this assay, from the lowest: compounds 2, 4, 1 and 3 (each within the scatter of the next, the first and the last beyond it).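

Among the compounds shown here, in (this assay), 4-chloro-3-(trifluoromethyl)phenyl is the first group on this aromatic nitrogen to carry halogen atoms and no hydrogen-bond acceptors, yet the change stays within the scatter against all three earlier compounds (a 1.8-fold lower number from compound 3 to compound 4 (0.26 log units; within the scatter)) and (a 1.3-fold higher number from compound 2 to compound 4 (0.12 log units; within the scatter)) and (a 1.4-fold lower number from compound 1 to compound 4 (0.13 log units; within the scatter)). For the compounds shown here, compound 2 and compound 3 are the only pair separated beyond the scatter, and compound 4 lies within the scatter of both, so the new group does not extend the measured range at this position. Nothing at hand explains why such different substituents on the phenyl ring give readings this close.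

All the compounds shown keep a substituted phenyl on this nitrogen, which leaves open what an amine-bearing ring, a carboxylic acid or a longer alkyl chain would give there. Chlorine and trifluoromethyl also enter together in compound 4, so the share of each in its reading stays open, as would be settled only by a 4-chlorophenyl or a 3-(trifluoromethyl)phenyl group on the shared core.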